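A Pyridine Ring Returns to a Sparse Amine Position

The compounds below may be only part of what the source reports. "The series", "measured", "known", "first", "only" and "open" are said of these compounds alone.

Among the measured compounds shown here, the three compounds measured so far share one core, seen in compound 3, `CN1CCC[C@H](OCc2cc(Cl)cc(Cl)c2)[C@@H]1c1ccccc1`, where a plain hydrogen sits on the saturated chain carbon bound to the ring amine nitrogen. In an assay on isolated protein for activation of cGMP-dependent protein kinase 1 (Homo sapiens), read by ADP-Glo, with stated times of 120 min and 40 min (a higher number here means that more compound is needed for the effect, a lower number that less compound is needed), compound 3 gives only a limit, > 200000 nM, and not a number. Compound 1, `O=C(O)c1ccc(CN2CCC[C@H](OCc3cc(Cl)cc(Cl)c3)[C@@H]2c2ccccc2)s1`, carries a 5-carboxythiophen-2-yl group at that position, and in this assay compound 1 gives 76000 nM. Compound 2, `Clc1cc(Cl)cc(CO[C@H]2CCCN(Cc3ccccn3)[C@H]2c2ccccc2)c1`, carries a pyridin-2-yl group there; in this assay compound 2 also gives only a limit, > 200000 nM. Two of the three values thus sit at the limit of > 200000 nM in this assay, at which 2 of the 3 values shown sit. Compound 4, `Clc1cc(Cl)cc(CO[C@H]2CCCN(Cc3cccnc3)[C@H]2c2ccccc2)c1`, is the next to be measured and differs from compound 3 in one place: pyridin-3-yl in place of hydrogen on a saturated chain carbon bound to an amine nitrogen in a ring. Of the measured steps, the nearest is an at least 2.6-fold higher number from compound 1 to compound 3 (0.42 log units; beyond the scatter), in which the loss of the ring at this position went with a weaker result, while a step that the two limits leave unreadable from compound 2 to compound 3. Compound 4 is expected to behave like compound 2, whose pyridine ring gave no number. The estimated step is a number no higher from compound 3 to compound 4 (the limit leaves the size open), none beyond the scatter. Compound 4 is therefore estimated at 200000 nM, within 80000 nM to 500000 nM, most likely reported again as a limit.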

Compound 4, half-maximal effective concentration: 112000 nM
Compound 4: the middle estimate sits 1.8-fold (0.25 log units) above what was measured; low and high end bracket the measured number.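

In this assay, the position on a saturated chain carbon bound to an amine nitrogen in a ring now holds a second group that returns a number, so the 5-carboxythiophen-2-yl group of compound 1, with its carboxylic acid, is no longer the only one that does. Against the plain hydrogen the result is an at least 1.7-fold lower number from compound 3 to compound 4 (0.25 log units; that floor lies within the scatter), and against the pyridin-2-yl group it is an at least 1.7-fold lower number from compound 2 to compound 4 (0.25 log units; that floor lies within the scatter); each of these is only a floor, since the other end of each step is a limit of the assay and not a number: the limit of > 200000 nM in this assay, at which 2 of the 4 values shown sit. Set against the acid-bearing group, the result is a 1.5-fold higher number from compound 1 to compound 4 (0.17 log units; within the scatter), so in this assay the pyridin-3-yl and 5-carboxythiophen-2-yl groups cannot be told apart.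

As far as these compounds go, whether moving the ring nitrogen from pyridin-2-yl to pyridin-3-yl truly changes the result stays open, as the floor does not clear the scatter. Also open, from the compounds shown here alone, is whether a pyridin-4-yl group, or a plain phenyl group, at this position would give a number, and how it would compare with the pyridin-3-yl group.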